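The compounds below may be only part of what the source reports. "The series", "measured", "known", "first", "only" and "open" are said of these compounds alone.

Two compounds of the shared core have numbers in a functional assay on HCT-116 cells (Homo sapiens) for cytotoxicity, read by crystal violet staining and colony formation, with a stated time of 7 days (a higher number here means a weaker inhibitor, a lower number a stronger inhibitor), so far. Compound 1 `COc1cc(OC)c(C2CC(c3c(O)ccc4ccccc34)=NN2c2ccc(Cl)cc2)cc1OC` gives 7800 nM in this assay. Compound 2 `COc1cccc(C2CC(c3ccc4ccccc4c3O)=NN2)c1OC` gives 15200 nM in this assay. Of the two numbers, compound 2 has the higher one, but compound 1 stands nearest to it and the gap between the two is within the scatter, so no order between them can be read from these values.

Compound 3 `COc1cccc(C2CC(c3ccc4ccccc4c3O)=NN2)c1` has not yet been measured in this assay. It differs from compound 2 in one place: hydrogen in place of methoxy on an aromatic carbon. For the measured compounds named here, no pair of measured compounds shows a change of this kind, so there is no measured step to lean on; what can be said is that the change removes a small group and keeps the rest of the structure unchanged. The expected step is a 1.0-fold lower number from compound 2 to compound 3 (0.01 log units; within the scatter), with no clear direction and not beyond the scatter. The value of compound 3 in this assay is estimated at 15000 nM, with a range from 5000 nM to 45000 nM.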

Compound 3, half-maximal inhibitory concentration: 20800 nM
Compound 3: middle estimate off by 1.4-fold (0.14 log units), on the low side; low and high end bracket the measured number.
By their numbers in this assay, from the lowest: compounds 1, 2 and 3 (each within the scatter of the next, the first and the last beyond it).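

In this assay, the series now has its first step between compounds that differ in one place: hydrogen in place of methoxy on an aromatic carbon, ortho to a large group and ortho to a methoxy group, gives a 1.4-fold higher number from compound 2 to compound 3 (0.14 log units; within the scatter). This step lies within the scatter, so for this pair the methoxy group at this position is not required to keep the number within the scatter of the value for compound 2, and the pair gives no direction for the change. No measurement on hand bears on the reason for this result.

The compounds shown leave open whether this aromatic carbon accepts other groups, such as an amine, a carboxylic acid or a longer chain such as ethoxy, without a step beyond the scatter. They also leave open whether hydrogen in place of methoxy gives a similar step with the other substituents found on compound 1, as this reading rests on a single pair.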